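This account rests on a few compounds, and the source may have more. Where it says the series, first, only, none or still open, it means among the compounds named here.

Working notes on the series, opening section.

Three compounds have numbers in an ADME assay on cells (Homo sapiens) for cytotoxicity (a higher number here means that more compound is tolerated, a lower number that less compound is tolerated), so far. Compound 1 `CCC1=C(C(=O)OCC2CCCCC2)[C@H](c2ccc(O)c(Cl)c2)NC(=O)N1` carries a cyclohexylmethoxy group on the carbonyl carbon. In this assay compound 1 reaches only the limit > 10000 nM. Compound 2 `O=C1NC2=C(C(=O)OC2)C(c2cccc(O)c2)N1` has a different core. In this assay compound 2 likewise gives only the limit > 10000 nM. Compound 3 `CCC1=C(C(=O)CCC2CCCCCC2)[C@H](c2ccc(O)c(Cl)c2)NC(=O)N1` carries 2-cycloheptylethyl on the carbonyl carbon in place of the cyclohexylmethoxy of compound 1. In this assay compound 3 also gives only the limit > 10000 nM.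

Among the compounds with values here, the one step between measured compounds that differ in a single place is a step that the two limits leave unreadable from compound 1 to compound 3; its size cannot be read, since both ends are limits. Compound 3 therefore stands at the limit, together with the two other values shown, as recorded in the limit of > 10000 nM in this assay, at which 3 of the 3 values shown sit.

The next compound, compound 4 `CCC1=C(C(=O)CC2CCCCC2)[C@H](c2ccc(O)c(Cl)c2)NC(=O)N1`, differs from compound 3 by cyclohexyl in place of cycloheptylmethyl on a saturated chain carbon bound to a carbonyl carbon. Within the data shown here, no measured step speaks to this change directly, because a step that the two limits leave unreadable from compound 1 to compound 3 is unreadable. Given that compound 3 sits at the limit > 10000 nM, the step that the limit leaves unreadable from compound 3 to compound 4 is expected to be no more than scatter. Compound 4 is thus estimated at 15000 nM, with a range from 7000 nM to 40000 nM, most likely reported again as a limit.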

Compound 4, half-maximal cytotoxic concentration: > 10000 nM
Compound 4 gave a limit, no number; the forecaster's own chance of this, stated with the estimate: 85%; the middle value does not contradict the limit.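

The steps from compound 3 to compound 4 and from compound 1 to compound 4 cannot be read, since both ends of each are limits: the limit of > 10000 nM in this assay, at which 4 of the 4 values shown sit.

The compounds shown leave open whether changing the group on the carbonyl carbon shifts the result in this assay at all, with no value other than a limit among them.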